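From fluoro to methyl in a well-tolerated series

The source may report more compounds than this note shows. Statements on the series, on what has been measured and on what is new or still open speak of the compounds shown alone.

In an ADME assay on MDCK cells (Canis lupus familiaris) for cytotoxicity (a higher number here means that more compound is tolerated, a lower number that less compound is tolerated), compound 2 (`CC(=O)Nc1ccc2oc(-c3ccnc(C(=O)N4CCN(C(c5ccc(F)cc5)c5nnn(C)n5)CC4)c3)nc2c1`) reads > 50000 nM as a limit of the assay and not as a number. Compound 1 (`CC(=O)Nc1ccc2oc(-c3ccnc(C(=O)N4CCC5(CC4)CCN(C(c4ccccc4)c4nnn(C)n4)CC5)c3)nc2c1`) reads > 50000 nM and this too is only a limit. Compound 3 (`CC(=O)Nc1ccc2oc(-c3ccnc(C(=O)N4CCN([C@@H](c5ccc(F)cc5)c5nnn(C)n5)CC4)c3)nc2c1`) reads > 200000 nM and this is again a limit. Compound 2 therefore has no exact place on the scale.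

Compound 4 (`CC(=O)Nc1ccc2oc(-c3ccnc(C(=O)N4CCN(C(c5ccc(C)cc5)c5nnn(C)n5)CC4)c3)nc2c1`) alters compound 2 in one place: methyl in place of fluoro on an aromatic carbon which means methyl in place of fluoro on an aromatic carbon, para to a large group.

Within the data shown here, only one measured step sits close to this change, and it is a step that the two limits leave unreadable from compound 2 to compound 3 with no size to carry over. That step rests on the fact that one of compounds 2 and 3 is drawn with a defined configuration and the other without, at the place where they differ and leaves the fluoro group untouched. Among the measured compounds shown here, no measured compound shows what methyl does here, so the expectation rests on where compound 2 stands. Compound 2 offers only > 50000 nM as a limit to start from. The estimated change is a step that the limit leaves unreadable from compound 2 to compound 4 and it is expected to stay within the usual scatter, with no direction to favour in this assay here. For compound 4 the expected value is 70000 nM with an estimated range from 35000 nM to 200000 nM and a report of only a limit is the likeliest outcome.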

Compound 4, half-maximal cytotoxic concentration: > 50000 nM
Compound 4 gave a limit, no number; the forecaster's own chance of this, stated with the estimate: 85%; the middle value does not contradict the limit.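

In this assay, compound 2 and compound 4 give no readable step, because neither has an exact value and both stop at the same limit: the limit of > 50000 nM in this assay, at which 3 of the 4 values shown sit.

On these data alone, whether 4-fluorophenyl and 4-methylphenyl differ at all in this assay remains open, as does the exact tolerated concentration of either compound.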